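The source may report more compounds than this note shows. Statements on the series, on what has been measured and on what is new or still open speak of the compounds shown alone.

Compound 1 `NS(=O)(=O)c1ccc(Nc2nc(N/N=C/c3ccc(C(F)(F)F)cc3)nc(Nc3ccccc3)n2)cc1` gives 2220 nM in a functional assay on 786-0 cells (Homo sapiens) for inhibition, read by sulforhodamine B assay, with a stated time of 48 h; a lower number here means a stronger inhibitor of growth, a higher number a weaker inhibitor of growth; compound 2 `Cc1nn(-c2ccccc2)cc1/C=N/Nc1nc(Nc2ccccc2)nc(Nc2ccc(S(N)(=O)=O)cc2)n1` gives 2130 nM in the same assay.

For the measured compounds named here, compound 2 stands level with compound 1, the only other compound measured here: a 1.0-fold lower number from compound 1 to compound 2 (0.02 log units; within the scatter) falls within the scatter. Compound 3 `NS(=O)(=O)c1ccc(Nc2nc(N/N=C/c3ccccn3)nc(Nc3ccccc3)n2)cc1` is obtained from compound 2 by the change (pyridin-2-yl in place of 3-methyl-1-phenyl-1H-pyrazol-4-yl on a carbon with a double bond to nitrogen). Going by the values given here, the one measured step at that same position, a 1.0-fold lower number from compound 1 to compound 2 (0.02 log units; within the scatter), exchanged a whole aromatic group there and left the growth inhibition unchanged beyond the scatter. On that single precedent, the expected step of a 1.0-fold higher number from compound 2 to compound 3 (0.01 log units; within the scatter) is none beyond the scatter. Compound 3 is therefore estimated at 2200 nM, within a range of 900 nM to 5500 nM.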

Compound 3, concentration for 50% growth inhibition: 1060 nM
For compound 3 the middle estimate is 2.1-fold (0.32 log units) above the measured one; the range from low to high includes it.
By their numbers in this assay, from the lowest: compounds 3, 2 and 1 (each within the scatter of the next, the first and the last beyond it).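

In this assay, putting pyridin-2-yl in place of 4-(trifluoromethyl)phenyl gives a 2.1-fold lower number from compound 1 to compound 3 (0.32 log units; beyond the scatter) and so the first modest shift at this position, which shows that exchanging one aromatic group for another here is not always without effect. Putting it in place of 3-methyl-1-phenyl-1H-pyrazol-4-yl gives a 2.0-fold lower number from compound 2 to compound 3 (0.30 log units; within the scatter) and so stays unresolved. Nothing shown explains the shift. Still open, on these data alone, is how this position responds to a group without an aromatic ring, such as an amine or a carboxylic acid, and whether plain phenyl would match pyridin-2-yl.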